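Shortening the nitrogen-bound chain: from ethyl to methyl

A few compounds are considered here, and "the series" means these few. Any claim that something is new, unique, unknown or untested is made for them only; others in the source may bear on it.

Measured so far:
compound 1 `Cn1c(-c2ccccc2)nc2c(NC3CCCC3)ncnc21` — 2.8 nM
compound 2 `CCCn1c(-c2ccccc2)nc2c(NC3CCOC3)ncnc21` — 25 nM
compound 3 `CCn1c(-c2ccccc2)nc2c(NC3CCOC3)ncnc21` — 10 nM

In an assay on CHO cells for displacement of a labelled ligand from adenosine receptor A1 (Homo sapiens), read by scintillation counting, with a stated time of 3 h (on this read-out lower numbers stand for stronger inhibition and higher numbers for weaker inhibition), compound 3 gives 10 nM, the second highest of the three numbers. Its nearest neighbour is compound 2 with 25 nM, and the furthest is compound 1 with 2.8 nM. Compound 4 `Cn1c(-c2ccccc2)nc2c(NC3CCOC3)ncnc21` is not yet measured. It differs from compound 3 by hydrogen in place of methyl on a saturated chain carbon bound to an aromatic nitrogen.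

Going by the values given here, one measured step bears on this: a 2.5-fold lower number from compound 2 to compound 3 (0.40 log units; beyond the scatter), where one carbon was also removed from the same chain. Compound 1, which carries a methyl on the aromatic nitrogen together with a different ring on the amine, shows the lowest number of all. Both point toward a lower number for compound 4 in this assay, and a step of about the same size is expected, a 2.0-fold lower number from compound 3 to compound 4 (0.30 log units; within the scatter). Compound 4 is therefore estimated at 5 nM, with a range from 2 nM to 12 nM.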

Compound 4, inhibition constant: 8 nM
Beside the measured number, compound 4's estimate is 1.6-fold (0.20 log units) below it; the measured number falls inside the stated range.
By their numbers in this assay, from the lowest: compound 1; then compounds 4 and 3 (each within the scatter of the next); then compound 2.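

In this assay, going from ethyl to methyl on this chain gives a 1.3-fold lower number from compound 3 to compound 4 (0.10 log units; within the scatter), so this last shortening cannot be told apart from repeat-measurement noise, whereas the preceding one, a 2.5-fold lower number from compound 2 to compound 3 (0.40 log units; beyond the scatter), lay beyond it. Over the whole shortening, hydrogen in place of ethyl on this chain carbon gives a 3.1-fold lower number from compound 2 to compound 4 (0.49 log units; beyond the scatter), a modest change that stands clear of the scatter. Going by these compounds alone, with methyl now held constant, the amine substituent can also be read on its own for the first time: oxolan-3-yl in place of cyclopentyl gives a 2.9-fold higher number from compound 1 to compound 4 (0.46 log units; beyond the scatter).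

Nothing available explains why these numbers differ. Still open, on these data alone, is how a bare hydrogen on the aromatic nitrogen, or a butyl chain there, would read, and whether the cyclopentyl effect holds with ethyl on that nitrogen.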